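This account rests on a few compounds, and the source may have more. Where it says the series, first, only, none or still open, it means among the compounds named here.

Measured in a functional assay on COLO 205 cells (Homo sapiens) for antiproliferative activity, read by MTT assay, with a stated time of 68 h; a higher number here means a weaker inhibitor, a lower number a stronger inhibitor:
compound 1 `O=S(=O)(Nc1ccc(F)c(C#Cc2cnc3[nH]ncc3c2)c1F)c1ccccc1F` gives 534 nM
compound 2 `O=S(=O)(Nc1ccc(F)c(C#Cc2cnc3[nH]ncc3c2)c1F)c1cccnc1` gives 445 nM
compound 3 `O=S(=O)(Nc1ccc(F)c(C#Cc2cnc3ccnn3c2)c1F)c1cccnc1` gives 1840 nM

Of the three, compound 3 has the highest number, 1840 nM, and is the weakest inhibitor in this assay. Compound 4 `Cc1n[nH]c2ncc(C#Cc3c(F)ccc(NS(=O)(=O)c4cccnc4)c3F)cc12` differs from it on the triple-bonded carbon: a group of 10 heavy atoms (7 carbon, 3 nitrogen; one five-membered aromatic ring with 2 hetero atoms, one six-membered aromatic ring with 1 hetero atom) in place of a group of 9 heavy atoms (6 carbon, 3 nitrogen; one five-membered aromatic ring with 2 hetero atoms, one six-membered aromatic ring with 2 hetero atoms), on a triple-bonded carbon.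

For the measured compounds named here, two measured steps bear on this. The closer one is a 4.1-fold higher number from compound 2 to compound 3 (0.62 log units; beyond the scatter). Going by the values given here, it falls at the same place, and the group entering compound 4 has the same ring types as the one in compound 2. The other, a 1.2-fold lower number from compound 1 to compound 2 (0.08 log units; within the scatter), concerns the group on the sulfonyl sulfur, which does not change here, so it adds little. Among the compounds with values here, no measured step isolates what remains between the group of compound 4 and that of compound 2.

A step of similar size, in the reverse direction, is therefore expected in this assay. The expected step is a 4.4-fold lower number from compound 3 to compound 4 (0.64 log units; beyond the scatter). The estimate for compound 4 is 420 nM, with an expected range of 130 nM to 1300 nM.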

Compound 4, half-maximal inhibitory concentration: 148 nM
Beside the measured number, compound 4's estimate is 2.8-fold (0.45 log units) above it; measured number inside the range.
By their numbers in this assay, from the lowest: compound 4; then compounds 2 and 1 (each within the scatter of the next); then compound 3.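

In this assay, for the compounds shown here, the added methyl on an aromatic carbon gives a 3.0-fold lower number from compound 2 to compound 4 (0.48 log units; beyond the scatter) and is the first change at this end of the molecule that lowers the number beyond the scatter, since the only earlier step at this place raised it. The step of a 12-fold lower number from compound 3 to compound 4 (1.09 log units; beyond the scatter) is the largest in the set, but it carries two differences at once, the ring make-up of the group on the triple-bonded carbon and the methyl, so it cannot be assigned to either alone. The sulfonyl group stays pyridin-3-yl throughout these two steps, so both gains belong to the group on the triple-bonded carbon.

On these data alone, whether ethyl, methoxy or an amine on that aromatic carbon would hold or extend the gain stays open, as does whether the methyl gives a similar step with 2-fluorophenyl on the sulfonyl sulfur. No measurement at hand accounts for either step.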